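The source may hold more compounds than are shown below. What is called first, only, known or untested is meant among the compounds shown, and "the series" means these compounds.

Compounds measured so far:
compound 1, `COC(=O)/C(=C\c1ccc(OC(=O)c2ccc(OC)cc2)cc1)Sc1ccnc2cc(Cl)ccc12`, 11000 nM
compound 2, `COC(=O)/C(=C\c1ccc(OC(=O)c2cc(OC)cc(OC)c2)cc1)Sc1ccnc2cc(Cl)ccc12`, 28900 nM
compound 3, `COC(=O)/C(=C\c1ccc(OC(=O)c2ccc(OC)c(OC)c2)cc1)Sc1ccnc2cc(Cl)ccc12`, 8290 nM

In a functional assay on Jurkat E6.1 cells (Homo sapiens) for cytotoxicity, read by MTT assay, with a stated time of 24 h (on this read-out higher numbers stand for weaker inhibition and lower numbers for stronger inhibition), compound 3 gives the lowest of the three numbers. Its nearest neighbour is compound 1, with a 1.3-fold lower number from compound 1 to compound 3 (0.12 log units; within the scatter), and the gap is within the scatter, so the two cannot be ordered. Compound 2 stands furthest away, with a 3.5-fold lower number from compound 2 to compound 3 (0.54 log units; beyond the scatter), a modest step beyond the scatter.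

Compound 4, `COC(=O)/C(=C\c1ccc(OC(=O)c2cc(OC)cc(OC)c2OC)cc1)Sc1ccnc2cc(Cl)ccc12`, is not yet measured. It differs from compound 3 in one place: 2,3,5-trimethoxyphenyl in place of 3,4-dimethoxyphenyl on a carbonyl carbon.

Two of the measured steps alter the same aromatic ring on the carbonyl carbon. Going from compound 1 to compound 2 gave a 2.6-fold higher number from compound 1 to compound 2 (0.42 log units; beyond the scatter), and from compound 2 to compound 3 gave a 3.5-fold lower number from compound 2 to compound 3 (0.54 log units; beyond the scatter), modest steps in opposite directions; the third step, a 1.3-fold lower number from compound 1 to compound 3 (0.12 log units; within the scatter), stayed within the scatter. Changes of the methoxy pattern on this ring have therefore moved this assay only modestly. For compound 4 a step of about a 1.4-fold higher number from compound 3 to compound 4 (0.16 log units; within the scatter) is expected, small and uncertain in direction. Compound 4 is therefore estimated at 12000 nM, in the range 5000 nM to 30000 nM.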

Compound 4, half-maximal inhibitory concentration: 15600 nM
Estimate against measurement, compound 4: 1.3-fold (0.11 log units) below; the range from low to high includes it.
By their numbers in this assay, from the lowest: compounds 3, 1, 4 and 2 (each within the scatter of the next, the first and the last beyond it).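

In this assay, the 2,3,5-trimethoxyphenyl group on the carbonyl carbon stays within the scatter of all three other methoxy patterns, with a 1.9-fold higher number from compound 3 to compound 4 (0.27 log units; within the scatter), a 1.9-fold lower number from compound 2 to compound 4 (0.27 log units; within the scatter) and a 1.4-fold higher number from compound 1 to compound 4 (0.15 log units; within the scatter), so none of these pairs can be ordered. Among these compounds, this holds even though compound 2 and compound 3 stand apart beyond the scatter, which places compound 4 within reach of both ends of the series so far. Methoxy in place of hydrogen on an aromatic carbon can now be read in two settings, and the two readings agree: the same change on two cores in this assay, a 1.3-fold lower number (0.12 log units; within the scatter) from compound 1 to compound 3 and a 1.9-fold lower number (0.27 log units; within the scatter) from compound 2 to compound 4, 1.4-fold (0.14 log units) apart, within the scatter of two such steps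

As far as these compounds go, all four compounds carry only methoxy groups on this ring, so it remains open whether an amine, a carboxylic acid or a chlorine there would move the number beyond the scatter. From the compounds shown here alone, the unsubstituted phenyl ring also remains open as a reference point.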